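This account rests on a few compounds, and the source may have more. Where it says the series, first, only, none or still open, it means among the compounds named here.

Measured so far in a functional assay on A549 cells (Homo sapiens) for antiproliferative activity, read by MTT assay, with a stated time of 12 h; a higher number here means a weaker inhibitor, a lower number a stronger inhibitor:
- compound 1 `COc1ccc2c(=O)cc(/C=C/c3ccc(OC(F)(F)F)cc3)oc2c1` gives > 40000 nM
- compound 2 `COc1cc(OC)c2c(=O)cc(/C=C/c3ccc(F)cc3)oc2c1` gives 18600 nM
- compound 3 `COc1cc(OC)c2c(=O)cc(/C=C/c3ccc(Br)cc3)oc2c1` gives > 40000 nM

Compound 1 stands at the limit of > 40000 nM in this assay, at which 2 of the 3 values shown sit; its value is a limit of this assay and not a number. Compound 3 sits at the same limit. Compound 2 is the only one of the three with a number in this assay. Going by the values given here, the single measured step between compounds differing in one place is an at least 2.1-fold higher number from compound 2 to compound 3 (0.33 log units; beyond the scatter), and it concerns the halogen on the pendant ring, not the core.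

Compound 4 `COc1ccc2c(=O)cc(/C=C/c3ccc(OC(F)(F)F)cc3)oc2c1OC` differs from compound 1 by methoxy in place of hydrogen on an aromatic carbon. Among the compounds with values here, no measured step covers this change: compounds 2 and 3 differ from compound 1 in more than one place, so the effect of the entering methoxy cannot be read from them. Compound 1 already sits at the limit, and with nothing shown that would move the number downward, compound 4 is expected to stay close to it; the expected step of an at least 1.1-fold lower number from compound 1 to compound 4 (0.05 log units; that floor lies within the scatter) is small or none beyond the scatter. Compound 4 is therefore estimated at 35000 nM, with a range from 12000 nM to 80000 nM, and a fair chance that this assay again reports only a limit.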

Compound 4, half-maximal inhibitory concentration: > 40000 nM
Compound 4 ended at the assay's limit; the forecaster's own chance of this, stated with the estimate: 60%; at least 1.1-fold (0.05 log units) between middle value and limit.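

In this assay compound 4 gives > 40000 nM, which is a limit of the assay and not a number. Compound 1 sits at the same limit, so the step between the two cannot be read: the limit of > 40000 nM in this assay, at which 3 of the 4 values shown sit.

The compounds shown leave open whether methoxy in place of hydrogen on an aromatic carbon changes the activity at all.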